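The compounds below may be only part of what the source reports. "The series", "measured", "known", "first", "only" and "open" are said of these compounds alone.

Measured compounds in an ADME assay on PANC-1 cells (Homo sapiens) for cytotoxicity, read by sulforhodamine B assay, with a stated time of 48 h, tested at 10 uM; on this read-out higher numbers stand for more inhibition at the one concentration tested (going by the name of the read-out) and lower numbers for less inhibition:
compound 1 `COc1nc2ccc(Br)cc2cc1C(c1ccccc1)n1cc(CCCO)nn1`, 25.5%
compound 2 `COc1nc2ccc(Br)cc2cc1C(c1ccccc1)n1cc(-c2cccc(F)c2)nn1`, 15.5%
compound 3 `COc1nc2ccc(Br)cc2cc1C(c1ccccc1)n1cc(CCCCCO)nn1`, 19.6%

Compound 1 carries the highest of the three numbers shown, but its steps to the other two both lie within the scatter: a number 10 percentage points lower from compound 1 to compound 2 (within the scatter) and a number 5.9 percentage points lower from compound 1 to compound 3 (within the scatter). On these numbers the three compounds are not separable.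

Compound 4 `COc1nc2ccc(Br)cc2cc1C(c1ccccc1)n1cc(C2CC2)nn1` differs from compound 1 at the same place that varies across compounds 1 to 3: cyclopropyl in place of 3-hydroxypropyl on an aromatic carbon. Going by the values given here, both measured steps that exchange the group at this place, 3-hydroxypropyl to 3-fluorophenyl and 3-hydroxypropyl to 5-hydroxypentyl, stayed within the scatter, and no step so far has gone beyond it. The exchange of 3-hydroxypropyl for cyclopropyl is expected to behave alike, so in this assay no step beyond the scatter is expected, the expected step being a number 5.5 percentage points lower from compound 1 to compound 4 (within the scatter). Compound 4 is accordingly expected to give about 20%, within a range of 8% to 32%.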

Compound 4, a percentage reported as inhibition, at one concentration (the size of the read-out at that concentration, not a potency): 21.8%
Compound 4: the middle estimate sits 1.8 percentage points below what was measured, and the stated range covers the measured number.
By their numbers in this assay, from the lowest: compounds 2, 3, 4 and 1 (each within the scatter of the next).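

Cyclopropyl brings a three-membered non-aromatic ring of carbon only, with 3 heavy atoms and 0 hydrogen-bond donors, onto the aromatic carbon, and in this assay the exchange for 3-hydroxypropyl gives a number 3.7 percentage points lower from compound 1 to compound 4 (within the scatter). Set against the other two groups, it gives a number 2.2 percentage points higher from compound 3 to compound 4 (within the scatter) and a number 6.3 percentage points higher from compound 2 to compound 4 (within the scatter), so this small saturated ring joins a hydroxy-bearing chain and 3-fluorophenyl in one unseparated set of four compounds, and the position has yet to show a step beyond the scatter. No supporting data bear on why these groups stay together.

From the compounds shown here alone, whether an amine or a carboxylic acid at this place would give a step beyond the scatter remains open. So does the effect of any change elsewhere on the shared core.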